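Replacing pyrrolidin-1-yl on the carbonyl carbon of compound 2

A few compounds are considered here, and "the series" means these few. Any claim that something is new, unique, unknown or untested is made for them only; others in the source may bear on it.

Of the compounds shown here, two that share one core have been measured so far: compound 1 `CCCCc1oc2ccccc2c1C(=O)c1ccc(OCC(=O)N2CCOCC2)cc1` and compound 2 `CCCCc1oc2ccccc2c1C(=O)c1ccc(OCCCC(=O)N2CCCC2)cc1` on the same footing. In a functional assay on MCF7 cells (Homo sapiens) for antiproliferative activity, read by MTT assay, with a stated time of 24 h (a higher number here means a weaker inhibitor, a lower number a stronger inhibitor), compound 1 gives 34000 nM as its value. Compound 2 gives 23500 nM as its value, which places it within the scatter of compound 1, so the two cannot be ranked.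

The next compound is compound 3 `CCCCc1oc2ccccc2c1C(=O)c1ccc(OCCCC(=O)N[C@@H](C)c2ccccc2)cc1` which keeps all of compound 2 except one group. Among the measured compounds shown here, there, (1-phenylethyl)amino stands in place of pyrrolidin-1-yl on a carbonyl carbon (1-phenylethyl)amino in place of pyrrolidin-1-yl on a carbonyl carbon as the single structural change.

For the measured compounds named here, only one measured step bears on this, and only loosely. That step is a 1.4-fold lower number from compound 1 to compound 2 (0.16 log units; within the scatter) and it put 2-((pyrrolidin-1-yl)carbonyl)ethyl in place of (morpholin-4-yl)carbonyl without leaving the scatter. Going by the values given here, no measured compound carries (1-phenylethyl)amino, so direct evidence is missing and the uncertainty is wide. In this assay no step beyond the scatter is therefore expected, and the estimated change is a 1.2-fold lower number from compound 2 to compound 3 (0.07 log units; within the scatter) in either reading of that range. The estimate for compound 3 is 20000 nM with 7000 nM to 50000 nM as its expected range.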

Compound 3, half-maximal inhibitory concentration: > 50000 nM
Compound 3 was reported as a limit; the forecaster's own chance of this, stated with the estimate: 10%; at least 2.5-fold (0.39 log units) between middle value and limit.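

In this assay, swapping pyrrolidin-1-yl for (1-phenylethyl)amino on the carbonyl carbon gives an at least 2.1-fold higher number from compound 2 to compound 3 (0.32 log units; beyond the scatter), the only step shown that lies beyond the scatter, whereas the earlier change, a 1.4-fold lower number from compound 1 to compound 2 (0.16 log units; within the scatter), could not be told apart from noise. The group on this carbonyl carbon can therefore matter for antiproliferative activity, and here the larger group, with its amide hydrogen and aromatic ring, goes with a weaker result rather than the small gain that might have been hoped for from so quiet a starting pair. For compound 3 the reading > 50000 nM is a limit and not a number, so the true size of the step stays unknown: the limit of > 50000 nM in this assay, at which 1 of the 3 values shown sits.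

The change brings in a six-membered aromatic ring, a hydrogen-bond donor and a defined stereocentre all at once, and the compounds shown cannot separate these three. As far as these compounds go, a methylamino or benzylamino group on the same carbonyl carbon, or the mirror-image form of the 1-phenylethyl group, would each isolate part of this change, and how those would read remains open.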